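This account rests on a few compounds, and the source may have more. Where it says the series, first, only, none or still open, it means among the compounds named here.

Series notes, measured in a physicochemical assay for solubility; on this read-out lower numbers stand for lower solubility and higher numbers for higher solubility:
- compound 1 `COCCN1CC[C@H](C)Nc2cc(ccc2C(N)=O)-n2c(c(C)c3c2CC(C)(C)CC3=O)CC1=O`: > 100 ug/mL
- compound 2 `Cc1c2c(n3c1CC(=O)N(CCN(C)C)CC[C@H](C)Nc1cc-3ccc1C(N)=O)CC(C)(C)CC2=O`: > 100 ug/mL
- compound 3 `Cc1c2c(n3c1CC(=O)N(C)CC[C@H](C)Nc1cc-3ccc1C(N)=O)CC(C)(C)CC2=O`: > 100 ug/mL

Compound 3 has only a limit, > 100 ug/mL, and no number. The same holds for the whole set, which shows (the limit of > 100 ug/mL in this assay, at which 3 of the 3 values shown sit). Its standing in this assay therefore cannot be ranked against compound 1 or compound 2.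

Compound 4 `CC(=O)NCCN1CC[C@H](C)Nc2cc(ccc2C(N)=O)-n2c(c(C)c3c2CC(C)(C)CC3=O)CC1=O` carries acetamidomethyl in place of hydrogen on a saturated chain carbon bound to an amide-type nitrogen in a ring.

Two measured changes fall at that same place: a step that the two limits leave unreadable from compound 1 to compound 3, and a step that the two limits leave unreadable from compound 2 to compound 3. The third, a step that the two limits leave unreadable from compound 1 to compound 2, concerns the end of the same chain. None of them has a readable size, so they give no direction for the new group. They do show that compound 1 and compound 2, which both carry a substituted chain at this place, remain at the limit, as compound 3 does without one.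

No step beyond the scatter is therefore expected, and the estimated step is a step that the limit leaves unreadable from compound 3 to compound 4. Another limit is the most likely report for compound 4. The expected value for compound 4 is 150 ug/mL, with an estimated range of 70 ug/mL to 300 ug/mL.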

Compound 4, solubility: > 100 ug/mL
Compound 4 ended at the assay's limit; the forecaster's own chance of this, stated with the estimate: 80%; the middle value is on the limit's open side.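

In this assay compound 4 gives > 100 ug/mL, which is a limit and not a number. No step from compound 1, compound 2 or compound 3 to compound 4 can be read: the limit of > 100 ug/mL in this assay, at which 4 of the 4 values shown sit.

The compounds shown leave open how these four rank in this assay, and how large any step at this chain is.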